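A bromo substituent added to the aryl ring of compound 3

This account rests on a few compounds, and the source may have more. Where it says the series, first, only, none or still open, it means among the compounds named here.

Of the compounds shown here, three sharing one core have been measured in a functional assay on WiDr cells (Homo sapiens) for inhibition, read by sulforhodamine B assay, with a stated time of 48 h; on this read-out higher numbers stand for weaker inhibition of growth and lower numbers for stronger inhibition of growth. Compound 1 `O=C(/C(=C/c1ccccc1)CCl)c1ccccc1` gives 18000 nM, compound 2 `CC(=O)OC/C(=C\C1CCCCC1)C(=O)c1ccccc1` gives 21000 nM, and compound 3 `CC(=O)OC/C(=C\c1ccccc1)C(=O)c1ccccc1` gives 17000 nM. Compound 3 thus carries the lowest of the three numbers, yet each of its neighbours stands within the scatter: the step of a 1.1-fold lower number from compound 1 to compound 3 (0.02 log units; within the scatter) and the step of a 1.2-fold lower number from compound 2 to compound 3 (0.09 log units; within the scatter) were both too small to count as real differences.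

Compound 4 `CC(=O)OC/C(=C\c1ccccc1Br)C(=O)c1ccccc1` differs from compound 3 only by bromo in place of hydrogen on an aromatic carbon. Among the measured compounds shown here, no measured step touches the phenyl ring on the double-bonded chain carbon, so nothing in the data speaks directly to this change. The two recorded steps, one at the saturated chain carbon and one exchanging the whole ring, both stayed within the scatter, which suggests the series is rather flat. The author therefore expects compound 4 to show a step of no change at the digits printed from compound 3 to compound 4 (within the scatter) in this assay, that is, nothing beyond the scatter. Compound 4 is estimated at 17000 nM, with a range from 6000 nM to 50000 nM.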

Compound 4, concentration for 50% growth inhibition: 21000 nM
Estimate against measurement, compound 4: 1.2-fold (0.09 log units) below; measured number inside the range.
By their numbers in this assay, from the lowest: compounds 3, 1, 2 and 4 (each within the scatter of the next).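

Bromo in place of hydrogen on an aromatic carbon, ortho to a large group, gives a 1.2-fold higher number from compound 3 to compound 4 (0.09 log units; within the scatter) in this assay, so the aromatic ring itself, which the earlier steps left untouched, shows no readable response to this change. The 2-bromophenyl group also stands level with cyclohexyl on the double-bonded chain carbon, with no change at the digits printed from compound 2 to compound 4 (within the scatter), which extends the flat picture to a substituted ring. The data shown offer no explanation for this outcome.

Still open, on these data alone, is whether an amine or a carboxylic acid in place of bromo on that aromatic carbon would move the number beyond the scatter. As far as these compounds go, it is equally open whether a longer chain in place of acetoxy on the saturated chain carbon would do so.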